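The source may hold more compounds than are shown below. What is called first, only, known or untested is meant among the compounds shown, and "the series" means these compounds.

Compound 1 `NC(=O)CC[C@H](NC(=O)CN(c1ncnc2c1ncn2C1CCCCO1)C1CC1)C(=O)OCc1ccccc1` gives 10.7%.
Compound 2 `CSCC[C@H](NC(=O)CN(c1nc(Cl)nc2[nH]cnc12)C1CC1)C(=O)O` gives 4.14%.

In a functional assay on the whole organism (Tail, strain ICR) with Mus musculus as the target, in the tail flick test, with a stated time of 150 min, at a dose of 25 umol/kg by the oral route (on this read-out higher numbers stand for a stronger effect at the one dose given and lower numbers for a weaker effect), compound 1 stands at the higher of the two numbers, yet its gap to compound 2 lies within the usual scatter, so the two cannot be ranked. Compound 3 `CC(C)[C@H](NC(=O)CN(c1ncnc2c1ncn2C1CCCCO1)C1CC1)C(=O)OCc1ccccc1` differs from compound 1 in one place: isopropyl in place of 2-carbamoylethyl on a saturated chain carbon bound to an amide-type nitrogen and a carbonyl carbon. Among the compounds with values here, no measured pair shows a change of this kind, so its effect is not known from the numbers at hand. The step from compound 1 to compound 3 is expected to be small, not beyond the scatter, a number 1.3 percentage points higher from compound 1 to compound 3 (within the scatter). Compound 3 is therefore estimated at 12%, within a range from 2% to 30%.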

Compound 3, a percentage reported as activity, at one dose (the size of the read-out at that dose, not a potency): 21.1%
For compound 3 the middle estimate is 9.1 percentage points below the measured one; measured number inside the range.
By their numbers in this assay, from the lowest: compounds 2 and 1 (each within the scatter of the next); then compound 3.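

In this assay, isopropyl in place of 2-carbamoylethyl gives a number 10.4 percentage points higher from compound 1 to compound 3 (beyond the scatter) and so shows that the effect responds to what this saturated chain carbon carries. Here the group with 3 heavy atoms and no hydrogen-bond donor or acceptor gives the higher number of the two, at the one dose tested. Nothing available explains this rise.

Still open, on these data alone, is how a plain butyl chain or a chain ending in an amine would behave at this carbon. A single-dose read-out also leaves the potency of compound 3 unknown.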